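Hydroxy in place of tert-butyl: expected cytotoxicity shift

The source may hold more compounds than are shown below. What is called first, only, known or untested is meant among the compounds shown, and "the series" means these compounds.

Compound 1 `COc1ccc(C(=O)N/N=C/c2cc(I)c(O)c(I)c2)cc1`; compound 2 `CC(C)(C)c1ccc(C(=O)N/N=C/c2cc(I)c(O)c(I)c2)cc1`; compound 3 `O=C(N/N=C/c1cc(I)c(O)c(I)c1)c1ccc(O)cc1`, not yet measured.

In a functional assay on HepG2 cells (Homo sapiens) for cytotoxicity, with a stated time of 24 h (a higher number here means a weaker inhibitor, a lower number a stronger inhibitor), compound 1 gives > 100000 nM, which is a limit of the assay rather than a number. In this assay compound 2 gives 45900 nM, the only actual number among these values. Among the measured compounds shown here, the single measured step is an at least 2.1-fold lower number from compound 1 to compound 2 (0.33 log units; beyond the scatter). Compound 3 carries hydroxy in place of tert-butyl on an aromatic carbon, a change running back in the direction that step came from. For compound 3 a higher number in this assay is therefore expected, the step of a 1.9-fold higher number from compound 2 to compound 3 (0.27 log units; within the scatter), possibly ending at the same limit (the limit of > 100000 nM in this assay, at which 1 of the 2 values shown sits). Compound 3 is estimated at 85000 nM, with a range from 30000 nM to 200000 nM.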

Compound 3, half-maximal inhibitory concentration: 110000 nM
For compound 3 the middle estimate is 1.3-fold (0.11 log units) below the measured one; low and high end bracket the measured number.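

In this assay, hydroxy in place of tert-butyl on this aromatic carbon gives a 2.4-fold higher number from compound 2 to compound 3 (0.38 log units; beyond the scatter). Among the compounds shown here, this is the only step at this position with a number at both ends, so its size does not rest on a limit. The step between compound 1 and compound 3 cannot be read, because compound 1 carries a limit of the assay: the limit of > 100000 nM in this assay, at which 1 of the 3 values shown sits.

Left open is where an amine, a carboxylic acid or an ethyl group on this aromatic carbon would fall relative to compound 2 and compound 3 in this assay. With only tert-butyl, methoxy and hydroxy shown here, no trend across groups can be drawn.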